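Methoxymethyl in Place of Methoxy: Expected Tolerance on Cells

The source may hold more compounds than are shown below. What is called first, only, known or untested is meant among the compounds shown, and "the series" means these compounds.

Measured so far:
compound 1 `Cc1c(Oc2ccccc2OCCn2ccc(=O)[nH]c2=O)cc(F)c2ccc(C#N)cc12`: > 100000 nM
compound 2 `COc1cc(Oc2ccccc2OCCn2ccc(=O)[nH]c2=O)c(C)c2cc(C#N)ccc12`: > 100000 nM

Both compounds were examined in a toxicity assay on MT2 cells (Homo sapiens) for cytotoxicity, read by MTT assay; a higher number here means that more compound is tolerated, a lower number that less compound is tolerated. In this assay compound 1 gives > 100000 nM, which is a limit of the assay rather than a number. Compound 2 gives > 100000 nM, again a limit. Within the data shown here, the step that the two limits leave unreadable from compound 1 to compound 2 is therefore of unreadable size, and the only thing the two values show is that both sit at the limit of > 100000 nM in this assay, at which 2 of the 2 values shown sit, so compound 2 stands at the limit, with no number of its own.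

Compound 3 `COCc1cc(Oc2ccccc2OCCn2ccc(=O)[nH]c2=O)c(C)c2cc(C#N)ccc12` differs from compound 2 by methoxymethyl in place of methoxy on an aromatic carbon. Among the measured compounds shown here, no measured step bears on this change, since the one step that exists is unreadable. With both neighbours at the limit, compound 3 is expected to stay there as well, giving an expected step of a number no higher from compound 2 to compound 3 (the limit leaves the size open) in this assay. The estimate for compound 3 is 100000 nM, in the range 50000 nM to 200000 nM.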

Compound 3, half-maximal cytotoxic concentration: 16000 nM
The estimate for compound 3 lay 6.3-fold (0.80 log units) above the measured number; measured number outside the range, below it.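

In this assay this position is not indifferent to what sits on it: methoxymethyl in place of methoxy brings an at least 6.2-fold lower number from compound 2 to compound 3 (0.79 log units; beyond the scatter) and so less compound is tolerated. Methoxymethyl in place of fluoro brings an at least 6.2-fold lower number from compound 1 to compound 3 (0.79 log units; beyond the scatter) and both sizes are only minimums, since each step starts from a limit and not from a number. The step between compound 1 and compound 2 cannot be read, and compound 3 is the only one shown with a number of its own, the other two sitting at the limit: the limit of > 100000 nM in this assay, at which 2 of the 3 values shown sit.

On these data alone, what in methoxymethyl matters stays open, since no other group at this position carries a number here. An amine, a hydroxymethyl or a longer chain such as ethoxymethyl on the same aromatic carbon would show whether tolerance falls further or returns to the limit.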